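The compounds below may be only part of what the source reports. "The series", "measured", "known", "first", "only" and "open" are said of these compounds alone.

Measured so far in a functional assay on ACHN cells (Homo sapiens) for cytotoxicity, read by sulforhodamine B assay, with a stated time of 72 h; on this read-out lower numbers stand for stronger inhibition of growth and higher numbers for weaker inhibition of growth:
- compound 1 `O=C(Nc1ccc(C(F)(F)F)cc1)C1CCc2ccccc2N1`: 25000 nM
- compound 2 `O=C(Nc1ccccc1C(F)(F)F)C1CCc2ccccc2N1`: 57600 nM

Of these two compounds, both of which carry a trifluoromethyl group, compound 2 has the higher number at 57600 nM. Its growth inhibition is therefore the weaker of the pair, and the gap to compound 1 at 25000 nM lies beyond the usual scatter.

The next compound to be considered is compound 3 `O=C(Nc1ccccc1)C1CCc2ccccc2N1`, which has hydrogen in place of trifluoromethyl on an aromatic carbon. The rest of the structure stays as it is in compound 2.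

Among the compounds with values here, no measured pair yet shows what this replacement does in this assay, so its size and direction remain open. The expectation therefore rests on compound 2 at 57600 nM as the closest measured neighbour, and no change beyond the scatter is anticipated. The expected step, a 1.0-fold higher number from compound 2 to compound 3 (0.02 log units; within the scatter), is an estimate that carries wide uncertainty in either direction. For compound 3 the estimated value is 60000 nM, with an expected range from 20000 nM to 150000 nM.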

Compound 3, concentration for 50% growth inhibition: 72900 nM
For compound 3 the middle estimate is 1.2-fold (0.08 log units) below the measured one; low and high end bracket the measured number.
By their numbers in this assay, from the lowest: compound 1; then compounds 2 and 3 (each within the scatter of the next).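

In this assay, replacing trifluoromethyl with hydrogen on an aromatic carbon, ortho to a large group, comes to a 1.3-fold higher number from compound 2 to compound 3 (0.10 log units; within the scatter), so the assay does not separate these two groups at this place. The same replacement, read from the trifluoromethyl group of compound 1, comes to a 2.9-fold higher number from compound 1 to compound 3 (0.46 log units; beyond the scatter), a modest step, which shows that the effect of removing trifluoromethyl depends on where the group stands, and compound 1 remains the only one of the three set apart from the others. No evidence is available that bears on why the two steps differ.

As far as these compounds go, the three compounds compare only trifluoromethyl and hydrogen on this aromatic ring, so it remains open whether a chlorine atom, a methoxy group, an amine or a carboxylic acid would move the number at either place. From the compounds shown here alone, it is also open whether changes elsewhere, at the amide hydrogen or on the shared core, would bring a larger step than the modest one seen for compound 1.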